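This account rests on a few compounds, and the source may have more. Where it says the series, first, only, none or still open, it means among the compounds named here.

Working notes on the series.

Compound 1 `O=C(Nc1cccc(-c2oc3cc(-c4ccc(F)cc4)ccc3c(=O)c2O)c1)c1ccc(F)cc1F` is the starting point. In a functional assay on A549 cells (Homo sapiens) for antiproliferative activity, read by CCK-8 assay, with a stated time of 72 h (a lower number here means a stronger inhibitor, a higher number a weaker inhibitor), compound 1 gives 20500 nM. The only other measured member, compound 2 `COc1cccc(C(=O)Nc2cccc(-c3oc4cc(-c5ccc(F)cc5)ccc4c(=O)c3O)c2)c1`, gives 10800 nM in this assay; the two numbers lie within the scatter of each other, so compound 1 is not set apart from compound 2 on the numbers shown.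

Compound 3 `Cc1cc(C(=O)Nc2cccc(-c3oc4cc(-c5ccc(F)cc5)ccc4c(=O)c3O)c2)ccc1F` differs from compound 1 as follows: 4-fluoro-3-methylphenyl in place of 2,4-difluorophenyl on a carbonyl carbon.

Going by the values given here, only one measured step touches the same carbonyl carbon, a 1.9-fold lower number from compound 1 to compound 2 (0.28 log units; within the scatter), and it did not leave the scatter. That step also swapped an aromatic ring on the carbonyl carbon, so it bears on the change to compound 3, but it gives no direction beyond noise. For compound 3 the expected step is a 1.4-fold lower number from compound 1 to compound 3 (0.14 log units; within the scatter), that is, no move beyond the scatter in this assay. The estimate for compound 3 in this assay is therefore 15000 nM, with a range from 6000 nM to 38000 nM.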

Compound 3, half-maximal inhibitory concentration: 11500 nM
Compound 3: the middle estimate sits 1.3-fold (0.12 log units) above what was measured, within the range that was stated.
By their numbers in this assay, from the lowest: compounds 2, 3 and 1 (each within the scatter of the next).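

At the carbonyl carbon, a third substituted phenyl ring now stands within the scatter of the other two in this assay (a 1.8-fold lower number from compound 1 to compound 3 (0.25 log units; within the scatter); a 1.1-fold higher number from compound 2 to compound 3 (0.03 log units; within the scatter)). Compound 1, compound 2 and compound 3 therefore show that, among these three rings, exchanging 2,4-difluorophenyl, 3-methoxyphenyl and 4-fluoro-3-methylphenyl gives no separation beyond the scatter, a statement limited to these compounds. No supporting data on the origin of these numbers accompany the series.

Going by these compounds, it remains open whether any group at this carbonyl carbon can move the number beyond the scatter, for instance a phenyl ring carrying a carboxylic acid or a dimethylamino group, or a saturated ring such as piperidine in place of the phenyl ring. The series also leaves open whether changes elsewhere on the core of compound 1 would do so.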